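A few compounds are considered here, and "the series" means these few. Any claim that something is new, unique, unknown or untested is made for them only; others in the source may bear on it.

Measured so far:
compound 1, `COc1cc(OC)cc(-c2cc3ccccc3c(-c3cccc(N)c3)n2)c1`, 13200 nM
compound 2, `COc1cc(OC)cc(-c2cc3ccccc3c(-c3ccc(O)cc3)n2)c1`, 4580 nM
compound 3, `COc1ccc(-c2cc3cc(C)ccc3c(-c3cccc(N)c3)n2)cc1OC`, 4190 nM

All three were tested in a functional assay on DU-145 cells (Homo sapiens) for cytotoxicity, read by CCK-8 assay and cell counting, with a stated time of 72 h; a higher number here means a weaker inhibitor, a lower number a stronger inhibitor. Compound 1 and compound 2 share one core and differ in a single place: 4-hydroxyphenyl in place of 3-aminophenyl on an aromatic carbon. That change gave a 2.9-fold lower number from compound 1 to compound 2 (0.46 log units; beyond the scatter). Compound 3 carries a different core; how the core of compound 3 differs from the core of compound 1 is not broken down here. Compound 3 and compound 2 give numbers within the scatter of each other, while compound 3 and compound 1 lie beyond it.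

Compound 4, `COc1ccc(-c2cc3cc(C)ccc3c(-c3ccc(O)cc3)n2)cc1OC`, is not yet measured. It stands to compound 3 as compound 2 stands to compound 1: 4-hydroxyphenyl in place of 3-aminophenyl on an aromatic carbon, at a place described in the same words for both pairs, so this is the same change made on the other core. Within the data shown here, from compound 3 to compound 4 a step of about a 2.3-fold lower number from compound 3 to compound 4 (0.37 log units; beyond the scatter) in this assay is expected, resting on the one earlier step of a 2.9-fold lower number from compound 1 to compound 2 (0.46 log units; beyond the scatter), which is the only example of this change seen here and may not carry over in full. Compound 4 is therefore expected to give about 1800 nM, most likely between 900 nM and 4500 nM.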

Compound 4, half-maximal inhibitory concentration: 5980 nM
Compound 4: middle estimate off by 3.3-fold (0.52 log units), on the low side; the measured number lies above the stated range.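

In this assay, placing 4-hydroxyphenyl where 3-aminophenyl stood on the second core gave a 1.4-fold higher number from compound 3 to compound 4 (0.15 log units; within the scatter), so the drop in number seen on the first core did not carry over. The two steps do not agree, which shows that in this series the result of this change depends on the core that carries it: the same change on two cores in this assay, a 2.9-fold lower number (0.46 log units; beyond the scatter) from compound 1 to compound 2 and a 1.4-fold higher number (0.15 log units; within the scatter) from compound 3 to compound 4, 4.1-fold (0.61 log units) apart, beyond the scatter of two such steps

This does not show which feature of the two cores sets the steps apart, and with a single pair on each core it cannot predict how the change would behave on a third core.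

The swap alters both the group on the phenyl ring and its numbered place on that ring, and the compounds shown do not separate these two effects. From the compounds shown here alone, it also stays open how either core would respond to a different group at this place, such as an unsubstituted phenyl or a phenyl bearing a carboxylic acid.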